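A few compounds are considered here, and "the series" means these few. Any claim that something is new, unique, unknown or untested is made for them only; others in the source may bear on it.

Compound 1 `Cn1c(-c2ccc(NC(=O)CSC3=NCCS3)cc2)nc(-c2ccccc2)c1-c1ccccc1`: 21 ug/mL
Compound 2 `CCN1CCN(CC(=O)Nc2ccc(-c3nc(-c4ccccc4)c(-c4ccccc4)n3C)cc2)CC1`: 75 ug/mL

In a functional assay on HT-29 cells (Homo sapiens) for cytotoxicity, read by MTT assay, with a stated time of 24 h (on this read-out higher numbers stand for weaker inhibition and lower numbers for stronger inhibition), compound 2 holds the higher of the two numbers, at 75 ug/mL, and compound 1 lies lower. Compound 3 `COc1ccc(CN2CCN(CC(=O)Nc3ccc(-c4nc(-c5ccccc5)c(-c5ccccc5)n4C)cc3)CC2)cc1` differs from it by 4-methoxyphenyl in place of methyl on a saturated chain carbon bound to an amine nitrogen in a ring. Among the compounds with values here, the only measured step, a 3.6-fold higher number from compound 1 to compound 2 (0.55 log units; beyond the scatter), lies at another place, so it guides size only. A similarly modest change is expected, tentatively toward a lower number. For compound 3 the expected step is a 1.7-fold lower number from compound 2 to compound 3 (0.22 log units; within the scatter). Compound 3 is estimated at 45 ug/mL, within a range of 15 ug/mL to 130 ug/mL.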

Compound 3, half-maximal inhibitory concentration: 77.3 ug/mL
Compound 3: the middle estimate sits 1.7-fold (0.23 log units) below what was measured, within the range that was stated.
By their numbers in this assay, from the lowest: compound 1; then compounds 2 and 3 (each within the scatter of the next).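

In this assay, 4-methoxyphenyl in place of methyl on a saturated chain carbon bound to an amine nitrogen in a ring gives a 1.0-fold higher number from compound 2 to compound 3 (0.01 log units; within the scatter), so compound 2 and compound 3 cannot be told apart. This place therefore takes a much larger group carrying an aromatic ring with no readable shift in the number, which the earlier step, made at another place, could not show. On these data alone, whether a plain benzyl, a 4-chlorobenzyl or a carboxylic acid in place of the 4-methoxybenzyl would also leave the number unmoved stays open. No measured evidence accounts for this result.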